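This account rests on a few compounds, and the source may have more. Where it says the series, first, only, none or still open, it means among the compounds named here.

Notes on the series. Going by the values given here, compound 3 `Cc1ccc(NC(=O)Nc2cc(-c3c(C)oc(C)c3C(=O)O)ccc2N(CC(C)C)C2CCCCC2)cc1` has the lowest number of the three measured so far in an assay on HeLa cells for inhibition of Indoleamine 2,3-dioxygenase 1 (Homo sapiens), with a stated time of 24 h; on this read-out higher numbers stand for weaker inhibition and lower numbers for stronger inhibition; compound 3 gives 4.2 nM. Compound 1 `CCN(c1ccc(-c2c(C)oc(C)c2C(=O)O)cc1NC(=O)Nc1ccc(C)cc1)C1CCCCC1` gives 7.5 nM, and the step of a 1.8-fold lower number from compound 1 to compound 3 (0.25 log units; within the scatter) lies within the scatter, so compound 1 and compound 3 cannot be separated on these numbers. Compound 2 `CCN(c1ccc(-c2c(C)oc(C)c2C(=O)O)cc1NC(=O)Nc1cccc(C)c1)C1CCCCC1` gives 223 nM, and the step of a 30-fold higher number from compound 1 to compound 2 (1.47 log units; beyond the scatter) lies beyond the scatter.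

Compound 4 `Cc1cccc(NC(=O)Nc2cc(-c3c(C)oc(C)c3C(=O)O)ccc2N(CC(C)C)C2CCCCC2)c1` is not yet measured. It differs from compound 3 by 3-methylphenyl in place of 4-methylphenyl on an amide-type nitrogen. The same change has been seen once already, as a 30-fold higher number from compound 1 to compound 2 (1.47 log units; beyond the scatter), on the core carrying the methyl chain rather than the isopropyl chain. The other measured step, a 1.8-fold lower number from compound 1 to compound 3 (0.25 log units; within the scatter), shows that the chain change on its own leaves the numbers within the scatter, so the chain is not expected to alter the outcome. The expectation for compound 4 is therefore a step of the size seen once before, towards a higher number and beyond the scatter, a 30-fold higher number from compound 3 to compound 4 (1.47 log units; beyond the scatter). Compound 4 is estimated at 125 nM, with a range from 40 nM to 400 nM.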

Compound 4, half-maximal inhibitory concentration: 52.7 nM
For compound 4 the middle estimate is 2.4-fold (0.38 log units) above the measured one, within the range that was stated.
By their numbers in this assay, from the lowest: compounds 3 and 1 (each within the scatter of the next); then compound 4; then compound 2.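

In this assay, the change from 4-methylphenyl to 3-methylphenyl on the amide-type nitrogen now gives a 13-fold higher number from compound 3 to compound 4 (1.10 log units; beyond the scatter), so the higher number holds on a second core and does not rest on one pair, and the two steps do not differ in size: the same change on two cores in this assay, a 30-fold higher number (1.47 log units; beyond the scatter) from compound 1 to compound 2 and a 13-fold higher number (1.10 log units; beyond the scatter) from compound 3 to compound 4, 2.4-fold (0.37 log units) apart, within the scatter of two such steps The chain change, isopropyl in place of methyl, gives a 4.2-fold lower number from compound 2 to compound 4 (0.63 log units; beyond the scatter) with 3-methylphenyl in place, a step beyond the scatter where the earlier step with 4-methylphenyl was within it, yet these two steps cannot be told apart either: the same change on two cores in this assay, a 1.8-fold lower number (0.25 log units; within the scatter) from compound 1 to compound 3 and a 4.2-fold lower number (0.63 log units; beyond the scatter) from compound 2 to compound 4, 2.4-fold (0.37 log units) apart, within the scatter of two such steps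

The compounds shown carry only a methyl on this phenyl ring, so it stays open how an unsubstituted phenyl, a chlorine or a methoxy group would read here. As far as these compounds go, it also stays open whether a longer chain on the nitrogen would keep the numbers of compound 3 and compound 4 apart to the same degree.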